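One group exchanged on compound 2

The compounds below may be only part of what the source reports. "The series", "measured", "known", "first", "only" and "open" are said of these compounds alone.

In a functional assay on DU-145 cells (Homo sapiens) for inhibition, read by trypan blue exclusion, with a stated time of 72 h (a higher number here means a weaker inhibitor, a lower number a stronger inhibitor), compound 1 (`Cn1c(=O)c(S(=O)(=O)c2ccc(F)cc2F)cc2cnc(Nc3ccc4occc4c3)nc21`) gives 15000 nM, compound 2 (`Cn1c(=O)c(S(=O)(=O)c2ccc(F)cc2F)cc2cnc(Nc3ccc4[nH]ncc4c3)nc21`) gives 30000 nM and compound 3 (`Cn1c(=O)c(S(=O)(=O)c2ccc(F)cc2)cc2cnc(Nc3ccc4[nH]ncc4c3)nc21`) gives 5000 nM. Compound 2 thus stands within the scatter of compound 1, and only compound 3 lies clearly apart from it, with a 6.0-fold lower number from compound 2 to compound 3 (0.78 log units; beyond the scatter). Among the measured compounds shown here, that step, hydrogen in place of fluoro on an aromatic carbon, is a different kind of change from the one in compound 4 (`Cn1c(=O)c(S(=O)(=O)c2ccc(F)cc2F)cc2cnc(Nc3cnc4[nH]ccc4c3)nc21`). Compound 4 differs from compound 2 on a nitrogen on an aromatic ring: a group of 9 heavy atoms (7 carbon, 2 nitrogen; one five-membered aromatic ring with 1 hetero atom, one six-membered aromatic ring with 1 hetero atom) in place of a group of 9 heavy atoms (7 carbon, 2 nitrogen; one five-membered aromatic ring with 2 hetero atoms, one six-membered aromatic ring of carbon only), on a nitrogen on an aromatic ring. For the measured compounds named here, the one measured exchange at that place gave a 2.0-fold higher number from compound 1 to compound 2 (0.30 log units; within the scatter). No shift beyond the scatter is therefore expected, and the estimated step is a 1.5-fold lower number from compound 2 to compound 4 (0.18 log units; within the scatter). For compound 4 the estimate is 20000 nM, with an expected range of 6000 nM to 60000 nM.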

Compound 4, half-maximal inhibitory concentration: 750 nM
The estimate for compound 4 lay 27-fold (1.43 log units) above the measured number; measured number outside the range, below it.
By their numbers in this assay, from the lowest: compound 4; then compound 3; then compounds 1 and 2 (each within the scatter of the next).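

With the same atoms joined differently in the group on this nitrogen, this assay gives a 40-fold lower number from compound 2 to compound 4 (1.60 log units; beyond the scatter) and a 20-fold lower number from compound 1 to compound 4 (1.30 log units; beyond the scatter) for the same exchange made against the other group. The earlier exchange here, 1H-indazol-5-yl in place of 1-benzofuran-5-yl, stayed within the scatter, so this place is sensitive to which group sits on it, and only the group with a hetero atom in each ring stands apart. No evidence bears on the reason for this large shift.

As far as these compounds go, it remains open whether hydrogen in place of fluoro on an aromatic carbon, the change that gave compound 3 from compound 2, would lower the number further for compound 4. From the compounds shown here alone, it also remains open whether a methoxy group or an amine on the entering group would keep the gain.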